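Aryl swap on the hydrazide nitrogen in two isomeric cores

The source may report more compounds than this note shows. Statements on the series, on what has been measured and on what is new or still open speak of the compounds shown alone.

Compound 1 `O=C(NNc1cccc(Cl)c1)c1cccc(NS(=O)(=O)c2cnc(O)nc2O)c1` and compound 3 `O=C(NNc1cccc(Cl)c1)c1ccccc1NS(=O)(=O)c1cnc(O)nc1O` are built from the same atoms joined differently; the difference between their two cores is not broken down here. In a functional assay on MDA-MB-231 cells (Homo sapiens) for antiproliferative activity, read by MTT assay, with a stated time of 24 h (on this read-out higher numbers stand for weaker inhibition and lower numbers for stronger inhibition), compound 1 gives 7760 nM. Compound 3 gives 11800 nM in this assay, a value within the scatter of compound 1. Compound 2 `O=C(NNc1ccccc1F)c1cccc(NS(=O)(=O)c2cnc(O)nc2O)c1` carries the change 2-fluorophenyl in place of 3-chlorophenyl on an amine nitrogen on the core of compound 1. For compound 2, this assay reports only a limit of > 20000 nM, not a number. The step of an at least 2.5-fold higher number from compound 1 to compound 2 (0.41 log units; beyond the scatter) therefore rests on that limit (the limit of > 20000 nM in this assay, at which 1 of the 3 values shown sits). Compound 4 `O=C(NNc1ccccc1F)c1ccccc1NS(=O)(=O)c1cnc(O)nc1O` carries the same change on the core of compound 3: 2-fluorophenyl in place of 3-chlorophenyl on an amine nitrogen. The place of the change reads alike in both pairs, so the change is the same in kind and in its surroundings. Starting from compound 3 at 11800 nM, a step of the size of an at least 2.5-fold higher number from compound 1 to compound 2 (0.41 log units; beyond the scatter) would carry compound 4 past the limit of this assay, so the expected step is a 2.5-fold higher number from compound 3 to compound 4 (0.41 log units; beyond the scatter). Compound 4 is expected to give 30000 nM, between 15000 nM and 80000 nM, most likely reported only as a limit.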

Compound 4, half-maximal inhibitory concentration: > 20000 nM
Compound 4: no number, only a limit; the forecaster's own chance of this, stated with the estimate: 70%; the middle value lies beyond the limit too.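

In this assay compound 4 gives > 20000 nM, which is a limit of the assay and not a number. The change of 3-chlorophenyl to 2-fluorophenyl on the amine nitrogen gives an at least 1.6-fold higher number from compound 3 to compound 4 (0.22 log units; that floor lies within the scatter), so the core of compound 3 does not go against the direction seen on the core of compound 1, but this floor alone does not establish a step beyond the scatter there. The result therefore shows agreement in direction at most, and it does not show that the change carries over with the same size: the same change on two cores in this assay, an at least 2.5-fold higher number (0.41 log units; beyond the scatter) from compound 1 to compound 2 and an at least 1.6-fold higher number (0.22 log units; that floor lies within the scatter) from compound 3 to compound 4; the limit leaves it open whether they differ.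

From the compounds shown here alone, with both 2-fluorophenyl compounds unresolved, the size of the change remains open on either core: the limit of > 20000 nM in this assay, at which 2 of the 4 values shown sit. The compounds shown also leave open whether the step follows the change of halogen or its place on the ring, a question that 2-chlorophenyl and 3-fluorophenyl groups on each core would separate.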